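The compounds below may be only part of what the source reports. "The series", "measured", "known", "first", "only" and "open" are said of these compounds alone.

Measured so far:
compound 1, `CCOC(=O)C1=C(C)N=C(S)NC1c1cccc([N+](=O)[O-])c1` — 84.9%
compound 2, `CCOC(=O)C1=C(C)NC(=S)NC1c1ccc(O)c([N+](=O)[O-])c1` — 62.4%

In a functional assay on aorta (Rattus norvegicus, strain Wistar) (on this read-out lower numbers stand for smaller maximal responses and higher numbers for larger maximal responses), compound 2 gives 62.4%, the lowest of the two numbers. The nearest number is that of compound 1, which gives 84.9%, a gap beyond the usual scatter.

Compound 3, `CCOC(=O)C1=C(C)NC(=S)NC1c1ccc(O)c(OC)c1`, is not yet measured. It differs from compound 2 in one place: methoxy in place of nitro on an aromatic carbon. Within the data shown here, no step of this kind has been measured, so its size is open. The expected step is a modest one, a number 7.6 percentage points higher from compound 2 to compound 3 (within the scatter), without a firm direction. For compound 3 the estimate is 70%, with a range from 50% to 90%.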

Compound 3, largest response reached (Emax), in percent of the reference or control that the assay uses: 78%
For compound 3 the middle estimate is 8 percentage points below the measured one, and the stated range covers the measured number.
By their numbers in this assay, from the lowest: compound 2; then compounds 3 and 1 (each within the scatter of the next).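

In this assay, methoxy in place of nitro on the aromatic carbon ortho to a hydroxy group gives a number 15.6 percentage points higher from compound 2 to compound 3 (beyond the scatter), the first step read at this position. The maximal response therefore depends on the group held there, at least across this one pair. No measured evidence accounts for the size or direction of this step.

From the compounds shown here alone, whether an amine, a carboxylic acid or a longer chain such as ethoxy at this position would give a lower or higher response remains open. Also open, going by these compounds, is whether the step persists without the neighbouring hydroxy group.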